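A few compounds are considered here, and "the series" means these few. Any claim that something is new, unique, unknown or untested is made for them only; others in the source may bear on it.

Measured in a functional assay on MIA PaCa-2 cells (Homo sapiens) for antiproliferative activity, read by WST assay, with a stated time of 72 h; a lower number here means a stronger inhibitor, a higher number a weaker inhibitor:
- compound 1 `Clc1ccc(-c2noc(-c3cc4ccccc4[nH]3)n2)cc1`: 19200 nM
- compound 2 `COc1ccc2[nH]c(-c3nc(-c4ccc(Cl)cc4)no3)cc2c1`: 22700 nM

Compound 2 sits at the higher of the two numbers in this assay, though its gap to compound 1 is within the scatter: a 1.2-fold higher number from compound 1 to compound 2 (0.07 log units; within the scatter). Compound 3 `COc1ccc(-c2noc(-c3cc4cc(OC)ccc4[nH]3)n2)cc1` differs from compound 2 by methoxy in place of chloro on an aromatic carbon. Within the data shown here, no measured step exchanges chloro for methoxy; the only step available changes a different position and is itself within the scatter. The change is therefore expected to leave compound 3 near compound 2 in this assay, with no shift beyond the scatter, a 1.1-fold higher number from compound 2 to compound 3 (0.04 log units; within the scatter). Compound 3 is estimated at 25000 nM, between 8000 nM and 80000 nM.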

Compound 3, half-maximal inhibitory concentration: 5600 nM
Compound 3: the middle estimate sits 4.5-fold (0.65 log units) above what was measured; measured number below the stated range.
By their numbers in this assay, from the lowest: compound 3; then compounds 1 and 2 (each within the scatter of the next).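

In this assay, among these compounds, the exchange of 4-chlorophenyl for 4-methoxyphenyl gives a 4.1-fold lower number from compound 2 to compound 3 (0.61 log units; beyond the scatter), the first step beyond the scatter. The earlier step, at a different position, stayed within it, so the series now shows that the number can respond to the group on this six-membered aromatic ring of carbon only, para to a large group. No evidence bears on the reason for this shift.

As far as these compounds go, whether an amine or a longer chain such as ethoxy at this position would hold the lower number remains open. Also open, from the compounds shown here alone, is whether the same exchange has a like effect on the core of compound 1.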